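The compounds below may be only part of what the source reports. "The series", "measured", "known", "first", "only" and "open" are said of these compounds alone.

Measured so far in a functional assay on PC-3 cells (Homo sapiens) for antiproliferative activity, read by MTT assay, with a stated time of 72 h; a higher number here means a weaker inhibitor, a lower number a stronger inhibitor:

- Compound 1 `C#CCSc1nc(Sc2nccs2)c(C#N)c(-c2ccc(Br)cc2)n1`: 8530 nM
- Compound 2 `C#CCSc1nc(Sc2nnnn2CCN(C)C)c(C#N)c(-c2cccc(Cl)c2)n1`: 3540 nM

With only these two results, compound 1 has the higher number and is therefore the weaker inhibitor. The gap between it and compound 2 is larger than the usual scatter of repeated measurements.

The next compound to be tested is compound 3 `C#CCSc1nc(Sc2nccs2)c(C#N)c(-c2ccc[nH]2)n1`. It keeps the core of compound 1, but 1H-pyrrol-2-yl takes the place of 4-bromophenyl on an aromatic carbon (1H-pyrrol-2-yl in place of 4-bromophenyl on an aromatic carbon).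

Among the compounds with values here, no pair of measured compounds differs in just one place, so the data offer no direct guide to the size or direction of this step. The only hint is indirect. Set against compound 1, which differs from it in more than one place, compound 2 gives 3540 nM, so those two changes together leave the number in a similar range.

A small step is therefore expected, with none beyond the scatter in this assay: the estimate is a 1.2-fold lower number from compound 1 to compound 3 (0.09 log units; within the scatter).

For compound 3, the estimated value is 7000 nM, with an expected range from 2500 nM to 20000 nM.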

Compound 3, half-maximal inhibitory concentration: > 20000 nM
Compound 3 was reported as a limit; the forecaster's own chance of this, stated with the estimate: 10%; middle value at least 2.8-fold (0.45 log units) from the limit.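

In this assay, placing 1H-pyrrol-2-yl instead of 4-bromophenyl on the aromatic carbon next to the ring nitrogen and ortho to a cyano group gives an at least 2.3-fold higher number from compound 1 to compound 3 (0.37 log units; beyond the scatter). This is the first change at a single place among these compounds, and it shows that the group on this carbon matters: one aromatic ring cannot simply be exchanged for another here without a clear loss of activity. The result for compound 3 is a limit of the assay and not a number, so the direction of the step is fixed while its full size remains unknown: the limit of > 20000 nM in this assay, at which 1 of the 3 values shown sits.

This single step changes several things at once, replacing a six-membered aromatic ring of carbon only, with its bromine, by a five-membered aromatic ring with one nitrogen and a hydrogen-bond donor, and the compounds shown cannot separate these differences. A plain phenyl ring or a thiophene ring on the same carbon, with the rest of compound 1 unchanged, would help show whether the loss follows the ring size, the bromine or the ring nitrogen with its hydrogen.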